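This account rests on a few compounds, and the source may have more. Where it says the series, first, only, none or still open, it means among the compounds named here.

Measured in a functional assay on CCRF-CEM cells (Homo sapiens) for antiproliferative activity, read by cell counting, with a stated time of 96 h; a higher number here means a weaker inhibitor, a lower number a stronger inhibitor:
- Compound 1 `CC(=O)c1ccc(Oc2ccccc2NC(C)=C2C(=O)CC(c3ccccc3)CC2=O)cc1`: 220 nM
- Compound 2 `COc1ccc(Oc2ccccc2NC(C)=C2C(=O)CC(c3ccccc3)CC2=O)cc1OC`: 160 nM
- Compound 3 `CCOc1ccccc1NC(C)=C1C(=O)CC(c2ccccc2)CC1=O`: 190 nM

These three values lie within the usual scatter of one another, so compound 1 cannot be ranked against the other two. Compound 4 `CC(Nc1ccccc1Oc1ccc(N)cc1)=C1C(=O)CC(c2ccccc2)CC1=O` has amino in place of acetyl on an aromatic carbon, para to a large group: amino in place of acetyl on an aromatic carbon. Within the data shown here, no measured compound carries this amino group. The closest evidence comes from replacing the whole 4-acetylphenyl group, which gave a 1.4-fold lower number from compound 1 to compound 2 (0.14 log units; within the scatter) and a 1.2-fold lower number from compound 1 to compound 3 (0.06 log units; within the scatter), both within the scatter. A change beyond the scatter is therefore not expected in this assay, and the expected step is a 1.2-fold lower number from compound 1 to compound 4 (0.09 log units; within the scatter). The estimate for compound 4 is 180 nM, with an expected range of 70 nM to 450 nM.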

Compound 4, half-maximal inhibitory concentration: 37 nM
For compound 4 the middle estimate is 4.9-fold (0.69 log units) above the measured one; the whole stated range lies above it.
By their numbers in this assay, from the lowest: compound 4; then compounds 2, 3 and 1 (each within the scatter of the next).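

Swapping the whole group on the oxygen had so far moved nothing beyond the scatter, yet amino in place of acetyl, para to a large group, gives a 5.9-fold lower number from compound 1 to compound 4 (0.77 log units; beyond the scatter) in this assay, so this position does respond to what it carries. The 4-aminophenyl group also stands apart from the other two, with a 5.1-fold lower number from compound 3 to compound 4 (0.71 log units; beyond the scatter) and a 4.3-fold lower number from compound 2 to compound 4 (0.64 log units; beyond the scatter), so a substituted phenyl on that oxygen is not enough by itself. Nothing measured here explains the gain. On these data alone, whether a hydroxyl, a methylamino or an acetamide at this place would do the same remains open.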